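Series notes: amide replacing aryl on the shared core

A few compounds are considered here, and "the series" means these few. Any claim that something is new, unique, unknown or untested is made for them only; others in the source may bear on it.

The shared core is a sulfonamide linking a chloro-methoxyphenyl ring to an aminopyridine. Compound 1 `COc1ccc(Cl)cc1S(=O)(=O)Nc1cncc(-c2cccnc2)c1` carries a pyridin-3-yl on the core; in an assay on isolated protein for inhibition of alkaline phosphatase, tissue-nonspecific isozyme (Homo sapiens) (a higher number here means a weaker inhibitor, a lower number a stronger inhibitor), compound 1 is recorded as "not determined" (no result reported). Compound 2 `COc1ccc(Cl)cc1S(=O)(=O)Nc1cncc(C(N)=O)c1` carries a carbamoyl at the same place, and in this assay compound 2 gives 105 nM. Within the data shown here, compound 3 `COc1ccc(Cl)cc1S(=O)(=O)Nc1cncc(-c2ccccc2C)c1` carries a 2-methylphenyl; in this assay compound 3 is recorded as "not determined" (no result reported), so compound 3 stands without a value, as does compound 1, and no step between measured compounds can be stated.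

Compound 4 `CCNC(=O)c1cncc(NS(=O)(=O)c2cc(Cl)ccc2OC)c1` differs from compound 3 in one place: ethylcarbamoyl in place of 2-methylphenyl on an aromatic carbon. Among the measured compounds shown here, since compound 3 has no value, the size and direction of this step in this assay cannot be computed; the only measured anchor is compound 2, whose carbamoyl is the closest counterpart of the entering ethylcarbamoyl. Resting on compound 2 at 105 nM, compound 4 is expected to give about 150 nM in this assay, with a range from 40 nM to 600 nM. A limit rather than a number is considered unlikely for compound 4.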

Compound 4, half-maximal inhibitory concentration: > 20000 nM
Compound 4 gave a limit, no number; the forecaster's own chance of this, stated with the estimate: 10%; middle value at least 130-fold (2.12 log units) from the limit.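

Series notes, continued: at this position the amide nitrogen proves far less permissive than compound 2 alone suggested, since ethyl in place of hydrogen on that nitrogen gives an at least 190-fold higher number from compound 2 to compound 4 (2.27 log units; beyond the scatter), a step beyond the scatter from one added group on an otherwise unchanged molecule. In this assay, from the compounds shown here alone, compound 4 gives > 20000 nM, which is a limit of the assay and not a number, so the step fixes only a minimum size and its true size stays unknown. Among the compounds shown, this is the only entry at that limit: the limit of > 20000 nM in this assay, at which 1 of the 4 values shown sits.

Compound 1 and compound 3 hold no value, so steps involving either of them, including the one from the 2-methylphenyl to the ethylcarbamoyl, cannot be read. Open as well is how much change the amide nitrogen accepts short of ethyl, and whether a methylcarbamoyl, a dimethylcarbamoyl or a carboxylic acid at the same place stays near compound 2 or falls to the same limit as compound 4.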